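Methyl on the pendant phenyl, carried over to a second core

The source may report more compounds than this note shows. Statements on the series, on what has been measured and on what is new or still open speak of the compounds shown alone.

Compound 1 `CCOC(=O)c1c(-c2c(Cl)c3cc(C)ccc3oc2=O)nn(-c2ccccc2)c1C(=O)OCC` and compound 2 `CCOC(=O)c1c(-c2c(Cl)c3cc(C)ccc3oc2=O)nn(-c2cccc(C)c2)c1C(=O)OCC` share one core; compound 3 `CCOC(=O)c1c(-c2cc3ccccc3oc2=O)nn(-c2ccccc2)c1C(=O)OCC` and compound 4 `CCOC(=O)c1c(-c2cc3ccccc3oc2=O)nn(-c2cccc(C)c2)c1C(=O)OCC` share another. The difference between the two cores is not broken down here. In a functional assay on A549 cells (Homo sapiens) for cytotoxicity, read by MTT assay, with a stated time of 48 h (a higher number here means a weaker inhibitor, a lower number a stronger inhibitor), compound 1 gives 108000 nM, compound 2 gives 115000 nM and compound 3 gives 100000 nM. Within the first pair the change methyl in place of hydrogen on an aromatic carbon gave a 1.1-fold higher number from compound 1 to compound 2 (0.03 log units; within the scatter). Compound 4 carries the same change, (methyl in place of hydrogen on an aromatic carbon), on the core of compound 3; the place of the change reads the same in both pairs. Among the compounds with values here, only this one measured pair informs the change. The expected step in this assay is a 1.1-fold higher number from compound 3 to compound 4 (0.03 log units; within the scatter), because a 1.1-fold higher number from compound 1 to compound 2 (0.03 log units; within the scatter) stayed within the scatter. Compound 4 is estimated at 108000 nM, with a likely range from 60000 nM to 200000 nM.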

Compound 4, half-maximal inhibitory concentration: 52000 nM
The estimate for compound 4 lay 2.1-fold (0.32 log units) above the measured number; the whole stated range lies above it.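

In this assay methyl in place of hydrogen on the second core gives a 1.9-fold lower number from compound 3 to compound 4 (0.28 log units; within the scatter) and the change does not separate the two cores: the same change on two cores in this assay, a 1.1-fold higher number (0.03 log units; within the scatter) from compound 1 to compound 2 and a 1.9-fold lower number (0.28 log units; within the scatter) from compound 3 to compound 4, 2.0-fold (0.31 log units) apart, within the scatter of two such steps. Within the data shown here, neither step shows an effect of the change from phenyl to 3-methylphenyl beyond the scatter, so the two cores agree in showing no measurable step. This rests on one pair per core and does not show that the change would behave alike on any further core.

From the compounds shown here alone, whether a group other than methyl on the pendant phenyl, such as an amine or a carboxylic acid, would give a step beyond the scatter stays open. Going by these compounds, what the difference between the two cores contributes on its own also stays open.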